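Cyclopropyl for 4-chlorophenyl on the ring amide nitrogen

The source may hold more compounds than are shown below. What is called first, only, known or untested is meant among the compounds shown, and "the series" means these compounds.

In a functional assay on HCT-116 cells (Homo sapiens) for antiproliferative activity, read by MTT assay, with a stated time of 72 h (a higher number here means a weaker inhibitor, a lower number a stronger inhibitor), compound 3 `O=C1COc2ccc(-c3cnc(Cl)c(NS(=O)(=O)c4ccc(F)cc4)c3)cc2N1c1ccc(Cl)cc1` gives 27900 nM and compound 2 `Cc1ccc(N2C(=O)COc3ccc(-c4cnc(Cl)c(NS(=O)(=O)c5ccc(F)cc5)c4)cc32)cc1` gives 34300 nM, level within the scatter: a 1.2-fold lower number from compound 2 to compound 3 (0.09 log units; within the scatter). Compound 1 `O=C1COc2ccc(-c3cnc(Cl)c(NS(=O)(=O)c4ccc(F)cc4)c3)cc2N1` reaches only a limit of the assay, > 40000 nM.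

Compound 4 `O=C1COc2ccc(-c3cnc(Cl)c(NS(=O)(=O)c4ccc(F)cc4)c3)cc2N1C1CC1` has cyclopropyl in place of 4-chlorophenyl on an amide-type nitrogen in a ring. Among the compounds with values here, the steps that bear on this position are an at least 1.1-fold lower number from compound 1 to compound 2 (0.06 log units; that floor lies within the scatter) and an at least 1.4-fold lower number from compound 1 to compound 3 (0.15 log units; that floor lies within the scatter). Both are floors within the scatter, so no large step is expected in this assay, and a limit remains possible. The expected step is a 1.3-fold higher number from compound 3 to compound 4 (0.11 log units; within the scatter). For compound 4 the estimated value is 36000 nM, with an expected range of 20000 nM to 60000 nM.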

Compound 4, half-maximal inhibitory concentration: 12400 nM
For compound 4 the middle estimate is 2.9-fold (0.46 log units) above the measured one, outside the stated range (below it).
By their numbers in this assay, from the lowest: compound 4; then compounds 3 and 2 (each within the scatter of the next). At a limit, above all of these: compound 1.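

In this assay, replacing either aryl group with cyclopropyl on the amide-type nitrogen gives steps beyond the scatter, though modest ones: a 2.3-fold lower number from compound 3 to compound 4 (0.35 log units; beyond the scatter) and a 2.8-fold lower number from compound 2 to compound 4 (0.44 log units; beyond the scatter). Against hydrogen at this position, the change gives an at least 3.2-fold lower number from compound 1 to compound 4 (0.50 log units; beyond the scatter). That step is only a floor, since compound 1 stands at a limit of the assay: the limit of > 40000 nM in this assay, at which 1 of the 4 values shown sits.

On these data alone, whether the lower number depends on the three-membered ring remains open, as an open chain such as ethyl or isopropyl could do the same. A chain ending in an amine is equally untested by the compounds shown.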